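Replacing a Hydroxy Group on a Shared Cytotoxic Core

The compounds below may be only part of what the source reports. "The series", "measured", "known", "first", "only" and "open" are said of these compounds alone.

Three compounds have been measured in a functional assay on HL-60 cells (Homo sapiens) for cytotoxicity, read by MTT assay, with a stated time of 3 days; a lower number here means a stronger inhibitor, a higher number a weaker inhibitor:
Compound 1, `N#Cc1c(O)nc(SCc2nc3ccccc3[nH]2)nc1-c1ccccc1`, gives 2.55 nM.
Compound 2, `N#Cc1c(Cl)nc(SCc2nc3ccccc3[nH]2)nc1-c1ccccc1`, gives 4.46 nM.
Compound 3, `N#Cc1c(Nc2ccccc2)nc(SCc2nc3ccccc3[nH]2)nc1-c1ccccc1`, gives 4.46 nM.

Compound 1 has the lowest number of the three, but the other two stand close by: a 1.7-fold higher number from compound 1 to compound 2 (0.24 log units; within the scatter) and a 1.7-fold higher number from compound 1 to compound 3 (0.24 log units; within the scatter). Both steps lie within the scatter, so none of the three can be called stronger or weaker than another. Between compounds 2 and 3 there is no change at the digits printed from compound 2 to compound 3 (within the scatter).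

Compound 4, `CN1CCN(c2nc(SCc3nc4ccccc4[nH]3)nc(-c3ccccc3)c2C#N)CC1`, has not yet been measured. It differs from compound 1 in one place: 4-methylpiperazin-1-yl in place of hydroxy on an aromatic carbon. Among the measured compounds shown here, two measured steps bear on this change, since both also replaced the hydroxy group at the same place, once with chloro and once with anilino. Neither moved the number beyond the scatter. No step beyond the scatter is expected here either, because a 1.7-fold higher number from compound 1 to compound 3 (0.24 log units; within the scatter) stayed within it; the expected step is a 1.6-fold higher number from compound 1 to compound 4 (0.20 log units; within the scatter). For the measured compounds named here, compound 4 is therefore estimated at 4 nM, with a range from 1.5 nM to 12 nM, the range being wide since only three numbers support it.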

Compound 4, half-maximal inhibitory concentration: 2.8 nM
Compound 4: the middle estimate sits 1.4-fold (0.15 log units) above what was measured, and the stated range covers the measured number.
By their numbers in this assay, from the lowest: compounds 1, 4, 2 and 3 (each within the scatter of the next).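

At this place, ortho to a cyano group, the change is far larger than the earlier ones: in this assay the 4-methylpiperazin-1-yl group brings 7 heavy atoms, a six-membered non-aromatic ring and 0 hydrogen-bond donors in place of the single heavy atom and 1 hydrogen-bond donor of hydroxy, and the result is still only a 1.1-fold higher number from compound 1 to compound 4 (0.04 log units; within the scatter). The same holds against the other two substituents, with a 1.6-fold lower number from compound 2 to compound 4 (0.20 log units; within the scatter) and a 1.6-fold lower number from compound 3 to compound 4 (0.20 log units; within the scatter), so a small atom, an aromatic amine and a saturated ring all fall within the scatter on this core. Nothing shown here explains why the number stays so flat at this place.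

Still open, going by these compounds, is whether some other kind of group at this place, such as a carboxylic acid or a longer alkyl chain, would move the number beyond the scatter. The four compounds also share the cyano group and the phenyl group, so they cannot tell how much those parts of the core contribute to the low numbers seen here.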